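A second methoxy on a compound at the limit

The source may hold more compounds than are shown below. What is called first, only, known or untested is meant among the compounds shown, and "the series" means these compounds.

In an ADME assay on K562 cells (Homo sapiens) for cytotoxicity, with a stated time of 72 h (on this read-out lower numbers stand for stronger inhibition and higher numbers for weaker inhibition), compound 3 (`COc1ccc(CNc2ncnc3c2ncn3C2CCCO2)cc1`) gives > 100000 nM and this is a limit, not a number. Compound 2 (`COc1cccc(CNc2ncnc3c2ncn3C2CCCO2)c1`) gives > 100000 nM and this too is a limit. Compound 1 (`COc1ccc(CNc2ncnc3c2ncn3C2CCCCO2)cc1OC`) gives > 100000 nM and this is also a limit. The whole measured set therefore rests on the limit of > 100000 nM in this assay, at which 3 of the 3 values shown sit, and offers no number to build on.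

The change to compound 4 (`COc1ccc(CNc2ncnc3c2ncn3C2CCCO2)cc1OC`) is methoxy in place of hydrogen on an aromatic carbon and it puts methoxy in place of hydrogen on an aromatic carbon, ortho to a methoxy group and meta to a large group. Among the measured compounds shown here, the only measured step that bears on it is a step that the two limits leave unreadable from compound 2 to compound 3 and it has no readable size. No step beyond the scatter is expected in this assay and no direction can be given. The step expected is a number no higher from compound 3 to compound 4 (the limit leaves the size open) and it is a rough estimate. Compound 4 is estimated at 100000 nM as a middle value. Its expected range runs from 50000 nM to 200000 nM and a further limit is the likeliest report.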

Compound 4, half-maximal inhibitory concentration: > 100000 nM
Compound 4 ended at the assay's limit; the forecaster's own chance of this, stated with the estimate: 90%; the middle value sits exactly at the limit.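

In this assay compound 4 gives > 100000 nM, which is a limit and not a number. Among the compounds shown here, no step to compound 4 from compound 1, compound 2 or compound 3 can be read: the limit of > 100000 nM in this assay, at which 4 of the 4 values shown sit. The compounds shown leave open whether the added methoxy changes the read-out at all.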